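Changing the Nitrogen Substituent of Compound 1

The source may report more compounds than this note shows. Statements on the series, on what has been measured and on what is new or still open speak of the compounds shown alone.

In a functional assay on MT4 cells (Homo sapiens) (on this read-out lower numbers stand for higher toxicity in this test and higher numbers for lower toxicity in this test), compound 1 (`Cc1cn([C@@H]2O[C@H](CO[Si](C)(C)C(C)(C)C)[C@@]3(OS(=O)(=O)C=C3NCC(N)=O)[C@H]2O[Si](C)(C)C(C)(C)C)c(=O)n(C)c1=O`) gives 14900 nM, which places it within the scatter of one neighbour and clearly apart from the other. Compound 3 (`COC(=O)NC1=CS(=O)(=O)O[C@@]12[C@@H](CO[Si](C)(C)C(C)(C)C)O[C@@H](n1cc(C)c(=O)n(C)c1=O)[C@@H]2O[Si](C)(C)C(C)(C)C`) gives 29900 nM, and the two cannot be separated: a 2.0-fold higher number from compound 1 to compound 3 (0.30 log units; within the scatter). Compound 2 (`CCOC(=O)CNC(=O)NC1=CS(=O)(=O)O[C@@]12[C@@H](CO[Si](C)(C)C(C)(C)C)O[C@@H](n1cc(C)c(=O)n(C)c1=O)[C@@H]2O[Si](C)(C)C(C)(C)C`) gives 3780 nM, the lowest of the three numbers: a 3.9-fold lower number from compound 1 to compound 2 (0.60 log units; beyond the scatter).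

Compound 4 (`COC(=O)CC(=O)NC1=CS(=O)(=O)O[C@@]12[C@@H](CO[Si](C)(C)C(C)(C)C)O[C@@H](n1cc(C)c(=O)n(C)c1=O)[C@@H]2O[Si](C)(C)C(C)(C)C`) has not yet been measured. It carries ((methoxycarbonyl)methyl)carbonyl in place of carbamoylmethyl on an amine nitrogen. Two measured replacements of carbamoylmethyl on that nitrogen bear on this change, and they point in different directions. Compound 2, whose new group also contains an ester, shows a modest fall, while compound 3 shows no shift beyond the scatter. These two also differ from each other: a 7.9-fold higher number from compound 2 to compound 3 (0.90 log units; beyond the scatter). The direction is therefore unsettled, and only a small step is expected in this assay. The expected step is a 1.5-fold lower number from compound 1 to compound 4 (0.17 log units; within the scatter). For compound 4 the estimated value is 10000 nM, with an expected range from 3000 nM to 35000 nM.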

Compound 4, half-maximal cytotoxic concentration: 11900 nM
Compound 4: the middle estimate sits 1.2-fold (0.08 log units) below what was measured, and the stated range covers the measured number.
By their numbers in this assay, from the lowest: compound 2; then compounds 4, 1 and 3 (each within the scatter of the next, the first and the last beyond it).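

In this assay, placing ((methoxycarbonyl)methyl)carbonyl on the amine nitrogen instead of carbamoylmethyl leaves the number within the scatter (a 1.3-fold lower number from compound 1 to compound 4 (0.10 log units; within the scatter)), even though the entering group is larger and carries no hydrogen-bond donor. What is attached to the carbonyl carbon still matters, since compound 4 stands apart from both of its closest relatives (a 2.5-fold lower number from compound 3 to compound 4 (0.40 log units; beyond the scatter)) and (a 3.1-fold higher number from compound 2 to compound 4 (0.50 log units; beyond the scatter)). An ester in the side group is therefore not enough on its own to give the low number of compound 2, and no measurement here explains these differences.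

As far as these compounds go, it remains open whether a carboxylic acid in place of the ester of compound 4 would shift the number in this assay. The effect of a longer chain between the carbonyl and the ester is equally unknown.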